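The source may hold more compounds than are shown below. What is called first, only, known or untested is meant among the compounds shown, and "the series" means these compounds.

Measured compounds:
Compound 1 `O=C1N/C(=N\c2ccc(Cl)cc2)S/C1=C/c1ccccc1O` — > 100000 nM in an ADME assay on cells (Homo sapiens) for antiproliferative activity (on this read-out lower numbers stand for stronger inhibition and higher numbers for weaker inhibition), a limit of the assay.
Compound 2 `COc1ccc(N=C2NC(=O)/C(=C\c3ccc(N(C)C)cc3)S2)cc1` — > 100000 nM, likewise a limit.
Compound 3 `COc1ccc(/C=C2/S/C(=N/c3ccccc3C)NC2=O)cc1` — 195000 nM.

Among the compounds with values here, compound 2 therefore has no number of its own; it sits at the limit of > 100000 nM in this assay, at which 2 of the 3 values shown sit, and the one compound with an actual number, compound 3, is also far from strong inhibition. Compound 4 `Cc1ccc(N=C2NC(=O)/C(=C\c3ccc(N(C)C)cc3)S2)cc1` is not yet measured. It differs from compound 2 by methyl in place of methoxy on an aromatic carbon. Within the data shown here, with no measured pair of compounds sharing this change, there is no basis to expect a step beyond the usual scatter, so compound 4 is expected to stay where compound 2 stands, with a step that the limit leaves unreadable from compound 2 to compound 4 as the estimated step. Compound 4 is estimated at 150000 nM, within a range from 50000 nM to 500000 nM.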

Compound 4, half-maximal inhibitory concentration: > 100000 nM
Compound 4 was reported as a limit; the forecaster's own chance of this, stated with the estimate: 70%; the middle value lies beyond the limit too.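

No step can be read from compound 2 to compound 4, since both values are limits and not numbers: the limit of > 100000 nM in this assay, at which 3 of the 4 values shown sit.

The compounds shown leave open whether methyl in place of methoxy changes inhibition at all in this assay.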